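The source may hold more compounds than are shown below. What is called first, only, known or untested is meant among the compounds shown, and "the series" means these compounds.

Three compounds of the series have numbers in a functional assay on HT-1080 cells (Homo sapiens) for cytotoxicity, read by MTT assay, with a stated time of 72 h; on this read-out higher numbers stand for weaker inhibition and lower numbers for stronger inhibition. Compound 1 (`COc1cccc(/C=C2\CCC/C(=C\c3ccc(Cl)cc3)C2=O)c1OC`) gives 11100 nM, compound 2 (`COc1cc(/C=C2\CCC/C(=C\c3cccc(OC)c3OC)C2=O)cc(OC)c1`) gives 4500 nM, and compound 3 (`COc1ccc(/C=C2\CCC/C(=C\c3cccc(O)c3)C2=O)cc1OC`) gives 1700 nM. Compound 3 therefore holds the lowest number of the three, and its gaps to compound 2 and to compound 1 both lie beyond the usual scatter.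

Among the measured compounds shown here, compound 4 (`COc1cc(/C=C2\CCC/C(=C\c3ccc(OC)c(OC)c3)C2=O)ccc1O`) has no measurement yet. It differs from compound 3 as follows: 4-hydroxy-3-methoxyphenyl in place of 3-hydroxyphenyl on a double-bonded chain carbon bound to a double-bonded ring carbon. In words, 4-hydroxy-3-methoxyphenyl stands in place of 3-hydroxyphenyl on a double-bonded chain carbon bound to a double-bonded ring carbon.

For the measured compounds named here, no two measured compounds differ in one place only, so no measured step gives the size of this change. Compound 4 carries a hydroxy group, as does compound 3 at 1700 nM, while compound 1 and compound 2 carry none. On that limited basis, the expected change in this assay is a 1.1-fold lower number from compound 3 to compound 4 (0.05 log units; within the scatter), with no step beyond the scatter and no firm direction. For compound 4 the estimate is 1500 nM, with an expected range from 500 nM to 5000 nM.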

Compound 4, half-maximal inhibitory concentration: 4600 nM
Estimate against measurement, compound 4: 3.1-fold (0.49 log units) below, within the range that was stated.
By their numbers in this assay, from the lowest: compound 3; then compounds 2 and 4 (each within the scatter of the next); then compound 1.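

In this assay, among the compounds shown here, 4-hydroxy-3-methoxyphenyl in place of 3-hydroxyphenyl on a double-bonded chain carbon bound to a double-bonded ring carbon gives a 2.7-fold higher number from compound 3 to compound 4 (0.43 log units; beyond the scatter), the first step that isolates one place, and it shows that this place responds to the choice of group. Both groups carry a hydroxy, so a hydroxy group at this place does not on its own preserve the number of compound 3. No measurement at hand accounts for the size or direction of this step.

The step joins two differences, the added methoxy and the changed hydroxy placement, and the compounds shown do not separate them. Also open, going by these compounds, is how an amine or a carboxylic acid in place of the hydroxy group would read at this place.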